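The source may report more compounds than this note shows. Statements on the series, on what has been measured and on what is new or still open speak of the compounds shown alone.

Values in a functional assay on A549 cells (Homo sapiens) for antiproliferative activity, read by MTT assay, with a stated time of 48 h (a lower number here means a stronger inhibitor, a higher number a weaker inhibitor), for the measured compounds:
compound 1 `COc1ccc(/C=C/c2cc(OC)cc(OC)c2/C=C/C(=O)c2cccc(OC)c2)cc1` gives 6.1 ug/mL
compound 2 `COc1ccc(/C=C/c2cc(OC)cc(OC)c2/C=C/C(=O)c2ccc(C)cc2)cc1` gives 3.6 ug/mL
compound 3 `COc1ccc(/C=C/c2cc(OC)cc(OC)c2/C=C/C(=O)c2ccc(OC)cc2)cc1` gives 4.5 ug/mL

The three values lie within the scatter of one another, so compound 3 stands apart from neither neighbour. Compound 4 `CCN(CC)c1ccc(C(=O)/C=C/c2c(/C=C/c3ccc(OC)cc3)cc(OC)cc2OC)cc1` carries diethylamino in place of methoxy on an aromatic carbon, para to a large group (diethylamino in place of methoxy on an aromatic carbon). Among the measured compounds shown here, two measured steps bear on this: a 1.3-fold higher number from compound 2 to compound 3 (0.10 log units; within the scatter), with methoxy in place of methyl on an aromatic carbon, and a 1.4-fold lower number from compound 1 to compound 3 (0.13 log units; within the scatter), both small. For the measured compounds named here, no measured compound carries diethylamino, so the expectation is loose. In this assay no change beyond the scatter is expected, the estimate being a 1.1-fold lower number from compound 3 to compound 4 (0.05 log units; within the scatter), with no firm direction. Compound 4 is estimated at 4 ug/mL (expected range 1.5 ug/mL to 10 ug/mL).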

Compound 4, half-maximal inhibitory concentration: 5.4 ug/mL
Compound 4: middle estimate off by 1.4-fold (0.13 log units), on the low side; the measured number falls inside the stated range.
By their numbers in this assay, from the lowest: compounds 2, 3, 4 and 1 (each within the scatter of the next).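

In this assay diethylamino in place of methoxy, on an aromatic carbon para to a large group, gives only a small step (a 1.2-fold higher number from compound 3 to compound 4 (0.08 log units; within the scatter)), so 5 heavy atoms in place of 2 at this position leave the number within the scatter. The other two comparisons with compound 4 also stay within the scatter (a 1.5-fold higher number from compound 2 to compound 4 (0.18 log units; within the scatter)) (a 1.1-fold lower number from compound 1 to compound 4 (0.05 log units; within the scatter)). Nothing available accounts for this result. From the compounds shown here alone, whether a carboxylic acid or a morpholine at this position would give a step beyond the scatter remains open.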